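Removing the Methoxy Group: a Shared Core at One Dose

This account rests on a few compounds, and the source may have more. Where it says the series, first, only, none or still open, it means among the compounds named here.

Of the compounds shown here, two sharing one core have been tested in a functional assay on the whole organism (strain Swiss albino) for inhibition, with Mus musculus as the target, with a stated time of 4 h; on this read-out higher numbers stand for an effect only at larger amounts of compound and lower numbers for an effect already at smaller amounts. Compound 1 `COc1ccc(-n2c(Nc3nc(-c4ccc([N+](=O)[O-])cc4)cs3)n[nH]c2=S)cc1` gives 300 mg/kg there, and compound 2 `COc1ccc(-n2c(Nc3nc(-c4ccccc4)cs3)n[nH]c2=S)cc1` gives 300 mg/kg, so compound 2 stands level with compound 1 at the digits printed. Going by the values given here, the single measured step, hydrogen in place of nitro on an aromatic carbon, reads no change at the digits printed from compound 1 to compound 2 (within the scatter), a change within the scatter.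

Compound 3 `S=c1[nH]nc(Nc2nc(-c3ccccc3)cs2)n1-c1ccccc1` has not yet been measured. It differs from compound 2 by hydrogen in place of methoxy on an aromatic carbon. Among the compounds with values here, the one step on record bears only loosely on this change, since it concerns a different group on the other aromatic ring, but it showed nothing beyond the scatter. Within the data shown here, no step in this set has yet moved the read-out. Compound 3 is therefore expected to give about 300 mg/kg in this assay, within 150 mg/kg to 600 mg/kg, which means an estimated step of no change at the digits printed from compound 2 to compound 3 (within the scatter).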

Compound 3, minimum effective dose: 300 mg/kg
The estimate for compound 3 equals the measured number at the digits printed, within the range that was stated.
By their numbers in this assay, from the lowest: compounds 1, 2 and 3 (each within the scatter of the next).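

In this assay, the change from 4-methoxyphenyl to phenyl, with hydrogen in place of methoxy on an aromatic carbon para to a large group, reads no change at the digits printed from compound 2 to compound 3 (within the scatter). Going by these compounds alone, the one earlier step concerned the other aromatic ring, so this is the first reading at this position, and it shows that compound 3 keeps 300 mg/kg with no methoxy group there. No measurement available here gives a reason for this result.

The compounds shown carry only methoxy or hydrogen at this position, so they leave open whether any group placed there could move the minimum effective dose at all. An amine, a carboxylic acid or a longer chain such as butoxy in place of the methoxy group remains an open case.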